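This account rests on a few compounds, and the source may have more. Where it says the series, first, only, none or still open, it means among the compounds named here.

Compound 1 `Nc1cc(N)c2nc(-c3ccccc3)c(Oc3ccc(Cl)c(Cl)c3)nc2c1` is the reference point of this account. In a functional assay on CAKI-1 cells (Homo sapiens) for inhibition, read by sulforhodamine B assay, with a stated time of 48 h (a higher number here means that more compound is tolerated, a lower number that less compound is tolerated), compound 1 gives < 100000 nM, and this is a limit of the assay rather than a measured number (the limit of < 100000 nM in this assay, at which 1 of the 3 values shown sits). Two further compounds sharing the core have numbers: compound 2 `CCOC(=O)[C@H](CCC(=O)O)NC(=O)c1ccc(Oc2nc3cc(N)cc(N)c3nc2-c2ccccc2)cc1` gives 31600 nM in this assay, and compound 3 `COc1ccc(CNc2nc3cc(N)cc(N)c3nc2-c2ccccc2)cc1OC` gives 53700 nM. Compound 4 `COc1ccc(Sc2nc3cc(N)cc(N)c3nc2-c2ccccc2)cc1` has not yet been measured. It differs from compound 1 in a single place: (4-methoxyphenyl)sulfanyl in place of 3,4-dichlorophenoxy on an aromatic carbon. Among the measured compounds shown here, no measured step matching this change is available, so in this assay the step is expected to be modest, likely within the scatter. Compound 4 is estimated to give 45000 nM, with a range from 20000 nM to 100000 nM. The expected step this implies is a step that the limit leaves unreadable from compound 1 to compound 4.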

Compound 4, concentration lethal to 50% of the cells: < 100000 nM
Compound 4 ended at the assay's limit; the forecaster's own chance of this, stated with the estimate: 30%; the middle value does not contradict the limit.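

Compound 4, like compound 1, stands at a limit rather than at a measured number in this assay, so no step can be read between the two: the limit of < 100000 nM in this assay, at which 2 of the 4 values shown sit. The compounds shown leave open how (4-methoxyphenyl)sulfanyl and 3,4-dichlorophenoxy compare in this assay.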